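Working notes: methoxy in place of chloro

The compounds below may be only part of what the source reports. "The series", "measured", "known", "first", "only" and "open" are said of these compounds alone.

compound 1 `NC1=NC2(CCSCC2)N(OCCCOc2cccc(Cl)c2)C(N)=N1`: 260 nM
compound 2 `NC1=NC2(CCSCC2)N(OCCCOc2ccc(Cl)cc2)C(N)=N1`: 430 nM

Going by the values given here, in a functional assay on HL-60 cells (Homo sapiens) for antiproliferative activity, read by MTT assay, with a stated time of 72 h (on this read-out higher numbers stand for weaker inhibition and lower numbers for stronger inhibition), compound 2, at 430 nM, stands within the scatter of compound 1, its only measured neighbour. Compound 3 `COc1ccc(OCCCON2C(N)=NC(N)=NC23CCSCC3)cc1` differs from compound 2 by methoxy in place of chloro on an aromatic carbon, with methoxy in place of chloro on an aromatic carbon, para to a large group. Among the compounds with values here, one measured step bears on this only indirectly: a 1.7-fold higher number from compound 1 to compound 2 (0.22 log units; within the scatter). Within the data shown here, it swaps 3-chlorophenyl for 4-chlorophenyl, so no measured step replaces chloro itself. No step beyond the scatter is therefore expected in this assay, and no direction can be called. The expected step is a 1.1-fold lower number from compound 2 to compound 3 (0.03 log units; within the scatter). Compound 3 is estimated at 400 nM, with an expected range of 150 nM to 1100 nM.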

Compound 3, half-maximal inhibitory concentration: 500 nM
The estimate for compound 3 lay 1.3-fold (0.10 log units) below the measured number; measured number inside the range.
By their numbers in this assay, from the lowest: compounds 1, 2 and 3 (each within the scatter of the next).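

In this assay, methoxy in place of chloro on an aromatic carbon, para to a large group, gives a 1.2-fold higher number from compound 2 to compound 3 (0.07 log units; within the scatter) as the first measured replacement of chloro itself. The change from 3-chlorophenyl to 4-methoxyphenyl gives a 1.9-fold higher number from compound 1 to compound 3 (0.28 log units; within the scatter) and adds no separation among the three groups shown. Nothing measured bears on why these numbers lie so close.
Still open, going by these compounds, is whether an amine or a carboxylic acid on this same aromatic carbon would produce a step beyond the scatter. Also open, on these data alone, is how 3-methoxyphenyl would compare with 3-chlorophenyl.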